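A few compounds are considered here, and "the series" means these few. Any claim that something is new, unique, unknown or untested is made for them only; others in the source may bear on it.

Measured in a functional assay on HCT-15 cells (Homo sapiens) for cytotoxicity, read by sulforhodamine B assay, with a stated time of 72 h; on this read-out lower numbers stand for stronger inhibition of growth and higher numbers for weaker inhibition of growth:
Compound 1 `CCCCCCCCC(=O)N1c2ccccc2CCC1C(=O)Nc1ccccc1C(F)(F)F` gives 7700 nM.
Compound 2 `O=C(Nc1ccccc1C(F)(F)F)C1CCc2ccccc2N1C(=O)c1ccc(Cl)cc1` gives 839 nM.
Compound 3 `CC(=O)N1c2ccccc2CCC1C(=O)Nc1ccccc1C(F)(F)F` reaches only the limit of the assay, > 80000 nM.

Compound 3 therefore stands at the weak end of the three, and its value is a limit rather than a number. Compound 4 `O=C(Nc1ccccc1C(F)(F)F)C1CCc2ccccc2N1C(=O)c1ccccc1Cl` has not been measured; it differs from compound 3 by 2-chlorophenyl in place of methyl on a carbonyl carbon. Going by the values given here, three measured steps bear on this change: an at least 95-fold higher number from compound 2 to compound 3 (1.97 log units; beyond the scatter), read in reverse, an at least 10-fold higher number from compound 1 to compound 3 (1.01 log units; beyond the scatter), and a 9.2-fold lower number from compound 1 to compound 2 (0.96 log units; beyond the scatter). Since an aryl group on that carbonyl carbon went with the lowest number seen, a large fall is expected for compound 4, of about an at least 53-fold lower number from compound 3 to compound 4 (1.72 log units; beyond the scatter). In this assay compound 4 is thus estimated at 1500 nM, with a likely range from 300 nM to 8000 nM.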

Compound 4, concentration for 50% growth inhibition: 4220 nM
Compound 4: the middle estimate sits 2.8-fold (0.45 log units) below what was measured, and the stated range covers the measured number.
By their numbers in this assay, from the lowest: compound 2; then compounds 4 and 1 (each within the scatter of the next). At a limit, above all of these: compound 3.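

Placing 2-chlorophenyl on the carbonyl carbon gives an at least 18-fold lower number from compound 3 to compound 4 (1.27 log units; beyond the scatter), so a second aryl group there also goes with a lower number than methyl does. Compound 3 stands only at a limit, so that step has no exact size: the limit of > 80000 nM in this assay, at which 1 of the 4 values shown sits. Aryl identity also counts, since 2-chlorophenyl in place of 4-chlorophenyl gives a 5.0-fold higher number from compound 2 to compound 4 (0.70 log units; beyond the scatter), whereas 2-chlorophenyl in place of octyl gives a 1.8-fold lower number from compound 1 to compound 4 (0.26 log units; within the scatter).

Open remains how an unsubstituted phenyl or a 3-chlorophenyl group would read on that carbonyl carbon. Also open, as far as these compounds go, is whether an amine on the aryl ring would change the number.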